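Lengthening the Acyl Chain on a Shared Core

The compounds below may be only part of what the source reports. "The series", "measured", "known", "first", "only" and "open" are said of these compounds alone.

Of the compounds shown here, three built on one shared core have been measured in a functional assay (Oryctolagus cuniculus) for inhibition of platelet-activating factor receptor (Cavia porcellus); on this read-out lower numbers stand for stronger inhibition and higher numbers for weaker inhibition. Compound 1 `CCCCCC(=O)OCC1CN(C(=O)c2cc(OC)c(OC)c(OC)c2)CCN1C(=O)c1cc(OC)c(OC)c(OC)c1` gives 290 nM, compound 2 `CCCCCCCC(=O)OCC1CN(C(=O)c2cc(OC)c(OC)c(OC)c2)CCN1C(=O)c1cc(OC)c(OC)c(OC)c1` gives 310 nM, and compound 3 `CCCCCCCCCC(=O)OCC1CN(C(=O)c2cc(OC)c(OC)c(OC)c2)CCN1C(=O)c1cc(OC)c(OC)c(OC)c1` gives 2820 nM. Compound 3 stands with the highest number of the three: the step of a 1.1-fold higher number from compound 1 to compound 2 (0.03 log units; within the scatter) stays within the scatter, whereas a 9.7-fold higher number from compound 1 to compound 3 (0.99 log units; beyond the scatter) and a 9.1-fold higher number from compound 2 to compound 3 (0.96 log units; beyond the scatter) both lie beyond it. Compound 4 `CCCCCCCCCCCCCCCCCC(=O)OCC1CN(C(=O)c2cc(OC)c(OC)c(OC)c2)CCN1C(=O)c1cc(OC)c(OC)c(OC)c1` carries the chain of compound 3 still further: octyl in place of hydrogen on a saturated chain carbon, nine bonds along the chain from a carbonyl carbon. Among the compounds with values here, the steps that bear on this change are the two that extend the chain past compound 2, namely a 9.1-fold higher number from compound 2 to compound 3 (0.96 log units; beyond the scatter) and a 9.7-fold higher number from compound 1 to compound 3 (0.99 log units; beyond the scatter), each a modest rise, while the shorter extension in a 1.1-fold higher number from compound 1 to compound 2 (0.03 log units; within the scatter) changed nothing beyond the scatter. Compound 4 adds a far longer piece than either of those steps did, so a further rise in this assay is expected, though whether the chain keeps costing as much with every extension cannot be read from three compounds alone. The expected step is a 3.5-fold higher number from compound 3 to compound 4 (0.55 log units; beyond the scatter). Compound 4 is accordingly estimated at 10000 nM, within a range from 2500 nM to 40000 nM.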

Compound 4, half-maximal inhibitory concentration: 45000 nM
Compound 4: the middle estimate sits 4.5-fold (0.65 log units) below what was measured, and the stated range ends below it.
By their numbers in this assay, from the lowest: compounds 1 and 2 (each within the scatter of the next); then compound 3; then compound 4.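

The octyl extension, on a saturated chain carbon nine bonds along the chain from a carbonyl carbon, shows that in this assay the rise seen at compound 3 does not level off: the number climbs again (a 16-fold higher number from compound 3 to compound 4 (1.20 log units; beyond the scatter)), a step printed as large where the earlier rises were modest. Set against the two shorter chains, the full effect of lengthening is much greater (a 150-fold higher number from compound 2 to compound 4 (2.16 log units; beyond the scatter); a 160-fold higher number from compound 1 to compound 4 (2.19 log units; beyond the scatter)), so among these four compounds the number rises beyond the scatter at each step past compound 2, while the step from compound 1 to compound 2 stays within it. Nothing available explains this rise or accounts for its size.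

As far as these compounds go, how the number moves across chain lengths between those of compound 3 and compound 4 remains open, so the four values cannot tell a steady climb from a sudden one. Also open, from the compounds shown here alone, is whether a chain shorter than that of compound 1 would give a lower number, and whether an amine or a carboxylic acid at the far end of the longest chain would change the result in this assay.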